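Removing trifluoromethyl from a branched amide side chain

The compounds below may be only part of what the source reports. "The series", "measured", "known", "first", "only" and "open" are said of these compounds alone.

Measured so far:
compound 1, `CCC(CNC(=O)c1ccc2c(c1)c(Cc1ccc(C(=O)NS(=O)(=O)c3ccccc3C)cc1OC)cn2C)CC(F)(F)F`: 9.6
compound 2, `COc1cc(C(=O)NS(=O)(=O)c2ccccc2C)ccc1Cc1cn(C)c2ccc(C(=O)NCC3CCCC3)cc12`: 8.4

Both compounds were tested in an assay on trachea for binding affinity to cysteinyl leukotriene receptor 1 (Cavia porcellus); on this read-out lower numbers stand for lower potency and higher numbers for higher potency (the scale is a negative logarithm). Compound 1 stands highest of the two numbers; the step of a number 1.20 log units lower from compound 1 to compound 2 (beyond the scatter) shows that swapping the branched fluorinated chain for a ring costs potency. Compound 3, `CCC(C)CNC(=O)c1ccc2c(c1)c(Cc1ccc(C(=O)NS(=O)(=O)c3ccccc3C)cc1OC)cn2C`, keeps the branched chain of compound 1 but loses its fluorinated end: hydrogen in place of trifluoromethyl on a saturated chain carbon, three bonds along the chain from an amide-type nitrogen. For the measured compounds named here, no measured pair tests this exact change, yet the one step available, from compound 1 to compound 2, shows that this side chain is sensitive to alteration, and the drop there was large. A smaller loss is therefore expected here, with compound 3 estimated to fall somewhat below compound 1, a step of a number 0.80 log units lower from compound 1 to compound 3 (beyond the scatter). For compound 3 the expected value in this assay is 8.8, with a likely range from 8.2 to 9.4.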

Compound 3, negative logarithm of the antagonist equilibrium constant: 8.7
The estimate for compound 3 lay 0.10 log units above the measured number, within the range that was stated.
By their numbers in this assay, from the lowest: compounds 2 and 3 (each within the scatter of the next); then compound 1.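

Removing only the trifluoromethyl while keeping the rest of the branched chain gives a number 0.90 log units lower from compound 1 to compound 3 (beyond the scatter) in this assay, so this single group accounts for a clear loss without any ring being introduced. Once that group is gone, the shape of the remaining side chain shows no clear effect: sec-butyl in place of cyclopentyl gives a number 0.30 log units higher from compound 2 to compound 3 (within the scatter), and these two compounds cannot be told apart on this read-out. Nothing available explains why the trifluoromethyl end matters.

The compounds shown leave open whether the whole trifluoromethyl is needed, or whether a difluoromethyl, a methyl or a longer fluorinated chain at this place would match compound 1 at 9.6 in this assay. A nitrile or a hydroxyl group there would test whether fluorine is required at all.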